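The compounds below may be only part of what the source reports. "The series", "measured", "known", "first", "only" and "open" are said of these compounds alone.

Measured so far in a functional assay on K562 cells (Homo sapiens) for inhibition; a lower number here means a stronger inhibitor, a higher number a weaker inhibitor
- compound 1 `COc1ccc(Cl)cc1-c1cc(Nc2ccc(Cl)cc2)nc(N)n1` gives 150 nM
- compound 2 `CCOc1ccc(Br)cc1-c1cc(Nc2cccc(C#N)c2)nc(N)n1` gives 350 nM
- compound 3 `CCOc1ccc(Cl)cc1-c1cc(Nc2ccc(CCCO)cc2)nc(N)n1` gives > 1000 nM

Compound 3 (> 1000 nM) is a limit of the assay and not a number. Of the two numbers, compound 2 (350 nM) is the higher, and the gap to compound 1 (150 nM) lies beyond the scatter.

Compound 4 (`CCOc1ccc(Br)cc1-c1cc(Nc2ccccc2)nc(N)n1`) follows from compound 2 with hydrogen in place of cyano on an aromatic carbon, 3-cyanophenyl to phenyl. For the measured compounds named here, no measured pair shows this change, so no direction is favoured. The expected step in this assay is (a 1.1-fold higher number from compound 2 to compound 4 (0.06 log units; within the scatter)), with none expected beyond the scatter. Compound 4 is estimated at 400 nM with an expected range from 150 nM to 1000 nM in this series.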

Compound 4, half-maximal inhibitory concentration: 260 nM
For compound 4 the middle estimate is 1.5-fold (0.19 log units) above the measured one; low and high end bracket the measured number.
By their numbers in this assay, from the lowest: compounds 1, 4 and 2 (each within the scatter of the next, the first and the last beyond it). At a limit, above all of these: compound 3.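

In this assay, the 3-cyanophenyl to phenyl change leaves the number within the scatter (a 1.3-fold lower number from compound 2 to compound 4 (0.13 log units; within the scatter)). For the compounds shown here, this is the first pair that differs in one place, and at this aromatic carbon it does not separate cyano from hydrogen, so the nitrile is not needed for a value in this range. Nothing measured here bears on why this step stays within the scatter.

On these data alone, whether an amine or a carboxylic acid on the same carbon would separate from hydrogen stays open. Compound 1 and compound 3 each differ from compound 4 in more than one place, so their other changes cannot be read singly.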